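This account rests on a few compounds, and the source may have more. Where it says the series, first, only, none or still open, it means among the compounds named here.

Compound 2 `C=C1CC[C@@H]2[C@](C)(CO)[C@H](O)CC[C@@]2(C)[C@@H]1C/C=C1/C(=O)OC[C@H]1Oc1cccc2ccc(C)nc12` is the starting point of this step. In an ADME assay on SNB-19 cells (Homo sapiens) for cytotoxicity, read by MTT assay, with a stated time of 24 h (on this read-out lower numbers stand for higher toxicity in this test and higher numbers for lower toxicity in this test), compound 2 gives only a limit, > 100000 nM, so no number is known for it. Compound 1 `C=C1CC[C@@H]2[C@](C)(CO)[C@H](O)CC[C@@]2(C)[C@@H]1C/C=C1/C(=O)OC[C@H]1Oc1cccnc1[N+](=O)[O-]`, the other measured compound, gives 67700 nM in this assay. Among the measured compounds shown here, the only measured step, an at least 1.4-fold higher number from compound 1 to compound 2 (0.16 log units; that floor lies within the scatter), exchanges one aryl ether for another and ends at the limit of > 100000 nM in this assay, at which 1 of the 2 values shown sits. Compound 3 `C=C1CC[C@@H]2[C@](C)(CO)[C@H](O)CC[C@@]2(C)[C@@H]1C/C=C1/C(=O)OC[C@H]1Oc1ccnc2ccccc12` differs from compound 2 by quinolin-4-yl in place of 2-methylquinolin-8-yl on an oxygen on a saturated carbon. For the measured compounds named here, no measured step exchanges one quinolinyl ether for another, so the measured step bears on this change only loosely; it shows that a change of the aromatic ether kept the number at the limit. Compound 3 is therefore expected to stay near that limit, with a number no higher from compound 2 to compound 3 (the limit leaves the size open) expected to lie within the scatter. The estimate for compound 3 in this assay is 100000 nM, within 40000 nM to 250000 nM.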

Compound 3, half-maximal cytotoxic concentration: 60100 nM
Beside the measured number, compound 3's estimate is 1.7-fold (0.22 log units) above it, and the stated range covers the measured number.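

Among the compounds shown here, the exchange of 2-methylquinolin-8-yl for quinolin-4-yl on this oxygen gives the first comparison between two quinolinyl ethers in this assay, and it reads an at least 1.6-fold lower number from compound 2 to compound 3 (0.22 log units; that floor lies within the scatter). Compound 2 remains a limit and not a number, so the true size of this step stays unknown, and the set still holds one such value: the limit of > 100000 nM in this assay, at which 1 of the 3 values shown sits.
The other new step, a 1.1-fold lower number from compound 1 to compound 3 (0.05 log units; within the scatter), shows that 2-nitropyridin-3-yl and quinolin-4-yl on this oxygen cannot be told apart on this read-out.

The two quinolinyl groups differ both in the methyl group and in the place of attachment, so the compounds shown do not separate these two changes. Also open, from the compounds shown here alone, is how the number would respond to an amine or a carboxylic acid on the quinoline.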